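From cyclopentyl to allyl on the amine nitrogen

A few compounds are considered here, and "the series" means these few. Any claim that something is new, unique, unknown or untested is made for them only; others in the source may bear on it.

In a functional assay (aorta) with Rattus norvegicus as the target (a lower number here means that less compound is needed, a higher number that more compound is needed for the effect), compound 3 `O=S1(=O)NC(NC2CCCC2)=Nc2ccc(F)cc21` gives 58 uM and holds the higher of the two numbers in the series. Compound 1 `CC(C)C(C)NC1=NS(=O)(=O)c2cc(F)ccc2N1` gives 26.4 uM as the nearest value, a lower number than that of compound 3. Compound 2 `O=S1(=O)NC(NC2CC2)=Nc2ccc(F)cc21` returns > 300 uM as its result, which is a limit of the assay and not a number.

Compound 4 `C=CCNC1=Nc2ccc(F)cc2S(=O)(=O)N1` differs from compound 3 in one place, with allyl in place of cyclopentyl on an amine nitrogen. The counted difference is allyl in place of cyclopentyl on an amine nitrogen and nothing else changes.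

Going by the values given here, the one measured step that bears on this is an at least 5.1-fold lower number from compound 2 to compound 3 (0.71 log units; beyond the scatter) and its size is only a bound, as one end is a limit. In that step, the compound with cyclopentyl has the lower number, and here cyclopentyl leaves. Among the compounds with values here, no allyl compound has been measured and allyl is not cyclopropyl, so that step carries over only loosely. Compound 4 may also return only a limit.

The expected step is a 2.2-fold higher number from compound 3 to compound 4 (0.35 log units; beyond the scatter) and it points to a higher number. For compound 4 the estimate is 130 uM with an expected range from 50 uM to 350 uM in these measurements.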

Compound 4, concentration for half-maximal effect: > 300 uM
Compound 4: only a limit was reported; the forecaster's own chance of this, stated with the estimate: 30%; at least 2.3-fold (0.36 log units) between middle value and limit.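

In this assay compound 4 returns > 300 uM, a limit of the assay and not a number, so allyl in place of cyclopentyl on the amine nitrogen gives an at least 5.1-fold higher number from compound 3 to compound 4 (0.71 log units; beyond the scatter), a size that is only a bound. This position now has two groups that give a readable number, cyclopentyl in compound 3 and the open branched chain in compound 1, and two that end at the limit, cyclopropyl in compound 2 and allyl in compound 4, so neither a ring nor an open chain alone sorts the series. The step from cyclopropyl to allyl cannot be read, because both of its ends sit at the limit: the limit of > 300 uM in this assay, at which 2 of the 4 values shown sit.

Going by these compounds, it remains open whether a saturated chain such as n-propyl or n-butyl, or a larger ring such as cyclohexyl, on the amine nitrogen would give a readable number or end at the limit. On these data alone, how far compound 2 and compound 4 lie from each other also stays unknown, and with it any order between cyclopropyl and allyl.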